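The compounds below may be only part of what the source reports. "The series", "measured", "known", "first", "only" and "open" are said of these compounds alone.

Measured in a functional assay on SK-OV-3 cells (Homo sapiens) for antiproliferative activity, read by MTT assay, with a stated time of 72 h; a lower number here means a stronger inhibitor, a higher number a weaker inhibitor:
Compound 1 `CC(C)(C)NC(=O)CCc1cccc2c1B(O)OC2`: > 100000 nM, a limit of the assay
Compound 2 `O=C(CCc1cccc2c1B(O)OC2)NC1CCCCC1`: > 100000 nM, a limit of the assay
Compound 3 `O=C(CCc1cccc2c1B(O)OC2)Nc1ccccc1`: 200 nM

Compound 3 is the only one of the three that gives a number in this assay. The next compound, compound 4 `O=C(CCc1cccc2c1B(O)OC2)NCc1ccccc1`, carries benzyl in place of phenyl on an amide-type nitrogen. The ring stays a six-membered aromatic ring of carbon only, and benzyl brings one more carbon.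

Among the measured compounds shown here, two measured steps bear on this change: an at least 500-fold lower number from compound 1 to compound 3 (2.69 log units; beyond the scatter) and an at least 500-fold lower number from compound 2 to compound 3 (2.69 log units; beyond the scatter). Both are large, and in both phenyl enters on the same amide-type nitrogen. The step that the two limits leave unreadable from compound 1 to compound 2 adds nothing on size. None of these steps tests benzyl itself, so the size of the change remains uncertain.

Benzyl keeps the aromatic ring, so compound 4 is not expected to lose everything that separates compound 3 200 nM from compound 1 and compound 2. Some weakening is still expected, with a higher number and a moderate step beyond the scatter. The expected change is a 10-fold higher number from compound 3 to compound 4 (1.00 log units; beyond the scatter). For compound 4 the estimated value is 2000 nM, with an expected range from 200 nM to 30000 nM.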

Compound 4, half-maximal inhibitory concentration: > 100000 nM
Compound 4 ended at the assay's limit; the forecaster's own chance of this, stated with the estimate: 20%; at least 50-fold (1.69 log units) between middle value and limit.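

In this assay, benzyl in place of phenyl on an amide-type nitrogen gives an at least 500-fold higher number from compound 3 to compound 4 (2.69 log units; beyond the scatter). The six-membered aromatic ring of carbon only is present in both compound 3 and compound 4, so among the compounds shown, that ring alone does not secure a measurable value, and one more carbon in the group separates a number from a limit. Compound 1, compound 2 and compound 4 share a single limit of the assay, and the steps among them cannot be read, leaving tert-butyl, cyclohexyl and benzyl unranked against one another: the limit of > 100000 nM in this assay, at which 3 of the 4 values shown sit.

As far as these compounds go, what remains open is how much of the activity of compound 3 depends on the unsubstituted phenyl itself, as a phenyl carrying a methoxy group or a chlorine on this nitrogen would show. From the compounds shown here alone, it is equally open whether the loss continues or reverses with a longer chain between the nitrogen and the ring, such as phenethyl.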